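A Nitrophenyl Replaces Dichlorophenyl on the Shared Core

The source may hold more compounds than are shown below. What is called first, only, known or untested is meant among the compounds shown, and "the series" means these compounds.

Compound 3 `COc1cc(/C=C/C(=O)C2=C(/C=C/c3ccc(O)c(OC)c3)NC(=O)NC2c2c(Cl)cccc2Cl)ccc1O` stands second highest of three compounds in a functional assay, with a stated time of 20 min, tested at 20 uM (a higher number here means a stronger effect of the compound at the concentration tested, a lower number a weaker effect), with 33%. Its nearest neighbour is compound 1 `COc1cc(/C=C/C(=O)C2=C(/C=C/c3ccc(O)c(OC)c3)NC(=O)NC2c2ccccc2)ccc1O` with 31%, and the gap between them is within the scatter: a number 2 percentage points higher from compound 1 to compound 3 (within the scatter). Its furthest neighbour is compound 2 `COc1cc(/C=C/C(=O)C2=C(/C=C/c3ccc(O)c(OC)c3)NC(=O)NC2c2ccc(N(C)C)cc2)ccc1O` with 82.2%, well beyond the scatter: a number 49.2 percentage points lower from compound 2 to compound 3 (beyond the scatter). Compound 4 `COc1cc(/C=C/C(=O)C2=C(/C=C/c3ccc(O)c(OC)c3)NC(=O)NC2c2cccc([N+](=O)[O-])c2)ccc1O` differs from compound 3 by 3-nitrophenyl in place of 2,6-dichlorophenyl on a saturated ring carbon. The two measured steps at this saturated ring carbon show that a change there can leave the read-out unmoved, as with phenyl, or shift it greatly, as with 4-(dimethylamino)phenyl. For the measured compounds named here, no measured compound carries a 3-nitrophenyl, so only a modest step is expected: a number 3 percentage points higher from compound 3 to compound 4 (within the scatter). Compound 4 is therefore estimated at 36%, within 18% to 62%.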

Compound 4, a percentage reported as activity, at one concentration (the size of the read-out at that concentration, not a potency): 33%
The estimate for compound 4 lay 3 percentage points above the measured number, and the stated range covers the measured number.
By their numbers in this assay, from the lowest: compounds 1, 3 and 4 (each within the scatter of the next); then compound 2.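

In this assay, 3-nitrophenyl in place of 2,6-dichlorophenyl gives no change at the digits printed from compound 3 to compound 4 (within the scatter) and nitro in place of hydrogen on the aromatic ring gives a number 2 percentage points higher from compound 1 to compound 4 (within the scatter) on this saturated ring carbon, so a third aromatic group now reads like phenyl and 2,6-dichlorophenyl. Among these compounds, 4-(dimethylamino)phenyl alone stands apart, with a number 49.2 percentage points lower from compound 2 to compound 4 (beyond the scatter) at this position. Still open, on these data alone, is whether a plain amine or a carboxylic acid on the same phenyl would also stand apart. No measured property bears on these results.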